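A few compounds are considered here, and "the series" means these few. Any claim that something is new, unique, unknown or untested is made for them only; others in the source may bear on it.

Measured so far:
compound 1 `CCNc1nc(-c2ccccc2)nc2c1nnn2Cc1ccccc1Cl`: 463000000 nM
compound 2 `COc1ccc(C(=O)Nc2nc(-c3ccccc3)nc3c2nnn3Cc2ccccc2Cl)cc1`: 20000000 nM
compound 3 `COc1ccc(C(=O)Nc2nc(-c3ccccc3)nc3c2nnn3Cc2ccccc2F)cc1`: 21900000 nM

All three were tested in an assay on isolated protein for binding affinity to adenosine receptor A1 (Bos taurus); on this read-out higher numbers stand for weaker inhibition and lower numbers for stronger inhibition. Compound 2 and compound 3 share one core and differ only by fluoro in place of chloro on an aromatic carbon, and their numbers lie close together: a 1.1-fold higher number from compound 2 to compound 3 (0.04 log units; within the scatter). Compound 1 differs from compound 2 by ethyl in place of (4-methoxyphenyl)carbonyl on a nitrogen on an aromatic ring, and here the number moves a long way: a 23-fold higher number from compound 2 to compound 1 (1.36 log units; beyond the scatter).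

Compound 4 `CCNc1nc(-c2ccccc2)nc2c1nnn2Cc1ccccc1F` has not yet been measured. It differs from compound 3 by ethyl in place of (4-methoxyphenyl)carbonyl on a nitrogen on an aromatic ring, the same change that separates compound 1 from compound 2, made at the same kind of place. The two cores on which the change is made differ by fluoro in place of chloro on an aromatic carbon, a difference that left the numbers of compound 2 and compound 3 within the scatter.

Because the earlier step of a 23-fold higher number from compound 2 to compound 1 (1.36 log units; beyond the scatter) was large and the cores behave alike, compound 4 is expected to show a step of similar size from compound 3, a 23-fold higher number from compound 3 to compound 4 (1.36 log units; beyond the scatter). For compound 4 the estimated value in this assay is 500000000 nM, expected to fall between 150000000 nM and 1500000000 nM.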

Compound 4, inhibition constant: 11000000 nM
Beside the measured number, compound 4's estimate is 45-fold (1.66 log units) above it; measured number below the stated range.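

In this assay, replacing (4-methoxyphenyl)carbonyl with ethyl on the fluoro-bearing core gives a 2.0-fold lower number from compound 3 to compound 4 (0.30 log units; within the scatter), which does not repeat the large step seen for the same change on the chloro-bearing core: the same change on two cores in this assay, a 23-fold higher number (1.36 log units; beyond the scatter) from compound 2 to compound 1 and a 2.0-fold lower number (0.30 log units; within the scatter) from compound 3 to compound 4, 46-fold (1.66 log units) apart, beyond the scatter of two such steps Read the other way, fluoro in place of chloro matters little when the nitrogen carries (4-methoxyphenyl)carbonyl, yet with ethyl there it gives a 42-fold lower number from compound 1 to compound 4 (1.62 log units; beyond the scatter): the same change on two cores in this assay, a 1.1-fold higher number (0.04 log units; within the scatter) from compound 2 to compound 3 and a 42-fold lower number (1.62 log units; beyond the scatter) from compound 1 to compound 4, 46-fold (1.66 log units) apart, beyond the scatter of two such steps So in these four compounds the size of each step depends on the group at the other place, and a step measured on one core cannot simply be carried to the other, but four compounds cannot show why this happens or whether compound 1 or compound 4 is the unusual one.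

Going by these compounds, it remains open which pattern other groups on that nitrogen would follow, such as a longer chain like propyl or a small acetyl. The same question holds for bromo or methyl in place of chloro and fluoro.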